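The source may hold more compounds than are shown below. What is called first, only, known or untested is meant among the compounds shown, and "the series" means these compounds.

Working notes on the series. Going by the values given here, compound 2 `C=C(C)C(CCC/C=C(\c1ccccc1)c1cccnc1)C(=O)O` gives 28 nM in an assay (Equus caballus) for inhibition of Thromboxane-A synthase (Homo sapiens), using microsomes (a higher number here means a weaker inhibitor, a lower number a stronger inhibitor), the lowest of the three numbers so far. Compound 1 `CSC(CCC/C=C(\c1ccccc1)c1cccnc1)C(=O)O` sits nearest, giving 30 nM, and the step of a 1.1-fold lower number from compound 1 to compound 2 (0.03 log units; within the scatter) lies within the scatter, so the two are not separated. Compound 3 `COC(=O)CCCC/C=C(\c1ccccc1)c1cccnc1` gives 100 nM, and the steps of a 3.3-fold higher number from compound 1 to compound 3 (0.52 log units; beyond the scatter) and a 3.6-fold higher number from compound 2 to compound 3 (0.55 log units; beyond the scatter) are modest but beyond the scatter.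

Compound 4 `O=C(O)C(CCC/C=C(\c1ccccc1)c1cccnc1)C1=CCCC1` differs from compound 2 by cyclopent-1-en-1-yl in place of 1-methylethenyl on a saturated chain carbon bound to a carbonyl carbon and a saturated chain carbon. The step bearing most directly on it is the exchange at the same place, a 1.1-fold lower number from compound 1 to compound 2 (0.03 log units; within the scatter), which did not move the number beyond the scatter; the larger steps to compound 3 involve a different exchange, so they bear only loosely. The change is therefore expected to give a 1.1-fold higher number from compound 2 to compound 4 (0.03 log units; within the scatter), that is no step beyond the scatter in either direction. Compound 4 is expected to give 30 nM, within a range of 10 nM to 90 nM.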

Compound 4, half-maximal inhibitory concentration: 60 nM
Compound 4: middle estimate off by 2.0-fold (0.30 log units), on the low side; the measured number falls inside the stated range.
By their numbers in this assay, from the lowest: compounds 2, 1, 4 and 3 (each within the scatter of the next, the first and the last beyond it).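

Going by these compounds alone, at the saturated chain carbon bound to a carbonyl carbon and a saturated chain carbon, cyclopent-1-en-1-yl in place of 1-methylethenyl gives a 2.1-fold higher number from compound 2 to compound 4 (0.33 log units; beyond the scatter), the first exchange at this place to pass the scatter, though only modestly. Cyclopent-1-en-1-yl in place of methylsulfanyl gives a 2.0-fold higher number from compound 1 to compound 4 (0.30 log units; within the scatter), which stays within the scatter, so the position accepts a five-membered ring with a number that separates compound 4 from compound 2 but not from compound 1. No supporting measurement bears on the reason for this step.

Still open, as far as these compounds go, is whether a saturated cyclopentyl, a phenyl or an amine on this carbon would give a similar number. The compounds shown also cannot separate the effect of the ring itself from that of the added carbons, which an open-chain group such as 1-ethylprop-1-en-1-yl could address.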